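Moving the chloro group around the aryl ring

The source may report more compounds than this note shows. Statements on the series, on what has been measured and on what is new or still open speak of the compounds shown alone.

Compound 1 `CC(C)(C)[C@H]1CC[C@]2(CC1)N=C(c1cccc(C(F)(F)F)c1)C(=O)N2Cc1ccc(C(=O)NCCC(=O)O)cc1`: 10000 nM
Compound 2 `CC(C)(C)[C@H]1CC[C@]2(CC1)N=C(c1cccc(Cl)c1)C(=O)N2Cc1ccc(C(=O)NCCC(=O)O)cc1`: > 10000 nM

In an assay on membranes from liver for displacement of a labelled ligand from Glucagon receptor (Mus musculus), read by scintillation counting, with a stated time of 60 min (a higher number here means a weaker inhibitor, a lower number a stronger inhibitor), compound 1 gives 10000 nM. From the compounds shown here alone, for compound 2 the assay reports only a limit, > 10000 nM, so its exact number is unknown. Among the compounds with values here, the single measured step, a number no lower from compound 1 to compound 2 (the limit leaves the size open), exchanges one group for another on the same aromatic carbon; the limit of > 10000 nM in this assay, at which 1 of the 2 values shown sits, leaves its size open. Compound 3 `CC(C)(C)[C@H]1CC[C@]2(CC1)N=C(c1ccc(Cl)cc1)C(=O)N2Cc1ccc(C(=O)NCCC(=O)O)cc1` has the same atoms as compound 2, joined differently: 4-chlorophenyl in place of 3-chlorophenyl on a carbon with a double bond to nitrogen. Within the data shown here, no measured step tests such a shift, and both measured compounds are weak inhibitors. The step of a number no higher from compound 2 to compound 3 (the limit leaves the size open) is therefore expected to stay within the scatter. Compound 3 is estimated at 10000 nM, between 3000 nM and 30000 nM.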

Compound 3, half-maximal inhibitory concentration: > 10000 nM
Compound 3 was reported as a limit; the forecaster's own chance of this, stated with the estimate: 60%; the middle value lies on the limit itself.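

In this assay compound 3 gives > 10000 nM, which is a limit and not a number, so 4-chlorophenyl gives no readable value at this position either. The step between the two chlorophenyl compounds cannot be read, as both values are limits: the limit of > 10000 nM in this assay, at which 2 of the 3 values shown sit. Exchanging 3-(trifluoromethyl)phenyl for 4-chlorophenyl gives a number no lower from compound 1 to compound 3 (the limit leaves the size open).

From the compounds shown here alone, whether the two chloro positions differ at all stays open. So does whether an amine or a nitrile on this aryl ring would give a readable value.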